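Nitro in Place of Ethyl: An Expected Step

This account rests on a few compounds, and the source may have more. Where it says the series, first, only, none or still open, it means among the compounds named here.

In a functional assay (Trachealis) for inhibition, with Cavia porcellus as the target (on this read-out higher numbers stand for weaker inhibition and lower numbers for stronger inhibition), compound 1 `C/C(=C\C#N)N[C@@H]1c2cc(C#N)ccc2OC(C)(C)[C@H]1O` gives 1230 nM. Compound 2 `CCc1cccn1C1=CC(C)(C)Oc2ccc(C#N)cc21` does not give a number in this assay but only a limit, > 20000 nM. This is the limit of > 20000 nM in this assay, at which 1 of the 2 values shown sits, so the value for compound 2 is a boundary of the measurement and not a figure that can be compared as such. Compound 3 `CC1(C)C=C(n2cccc2[N+](=O)[O-])c2cc(C#N)ccc2O1` has not been measured. It differs from compound 2 by nitro in place of ethyl on an aromatic carbon. For the measured compounds named here, no measured step between two compounds describes this change, so the size of the step in this assay for compound 3 is a matter of expectation only. Compound 3 is expected to remain near the limit of this assay, at an estimated 20000 nM with a range from 6000 nM to 60000 nM. This estimate means an expected step of a number no higher from compound 2 to compound 3 (the limit leaves the size open), not beyond the scatter.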

Compound 3, half-maximal inhibitory concentration: 690 nM
For compound 3 the middle estimate is 29-fold (1.46 log units) above the measured one; measured number outside the range, below it.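

On an aromatic carbon of the five-membered aromatic ring with 1 nitrogen, next to the ring nitrogen, the group carried makes a clear difference: in this assay, nitro in place of ethyl gives an at least 28-fold lower number from compound 2 to compound 3 (1.46 log units; beyond the scatter). The earlier compounds shown here showed no step at this position, and compound 2 alone could not show that a compound with this ring could give a measured number at all. The value for compound 2 is a limit, so the step has a lower bound but no exact size: the limit of > 20000 nM in this assay, at which 1 of the 3 values shown sits.

Going by these compounds, what an amine, a carboxylic acid or a longer chain would give at this position remains open. For the compounds shown here, with only this one pair, it also remains open which feature of nitro, or of the loss of ethyl, stands behind the step.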